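Two Ehrlich-cell cytotoxicity measurements and a sulfonamide analogue to come

The source may report more compounds than this note shows. Statements on the series, on what has been measured and on what is new or still open speak of the compounds shown alone.

Measured compounds:
compound 1 `N#CC1=C(NC(=S)Nc2ccc(Cl)cc2)N(c2ccc(S(N)(=O)=O)cc2)C2=C(C(=O)CCC2)C1c1ccc(Cl)cc1Cl` — 100%
compound 2 `N#CC1=C(N2C(=O)CCC2=O)N(c2ccc(S(N)(=O)=O)cc2)C2=C(C(=O)CCC2)C1c1ccc(Cl)cc1Cl` — 90%

Both compounds were examined in a functional assay on Ehrlich cells (Mus musculus) for cytotoxicity, read by trypan blue exclusion, with a stated time of 2 h, tested at 100 ug/mL; on this read-out higher numbers stand for a stronger effect at the one concentration tested and lower numbers for a weaker effect. Compound 1 gives 100% and compound 2 gives 90%. The only step between them, a number 10 percentage points lower from compound 1 to compound 2 (within the scatter), is within the scatter, so on the numbers shown compound 1 and compound 2 cannot be set apart from each other; compound 1 simply carries the larger of two numbers that agree within the usual variation.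

Compound 3 `N#CC1=C(NS(=O)(=O)c2ccc([N+](=O)[O-])cc2)N(c2ccc(S(N)(=O)=O)cc2)C2=C(C(=O)CCC2)C1c1ccc(Cl)cc1Cl` has not yet been measured in this assay. It differs from compound 1 in one place: a group of 12 heavy atoms (6 carbon, 1 nitrogen, 4 oxygen, 1 sulfur; one six-membered aromatic ring of carbon only) in place of a group of 10 heavy atoms (7 carbon, 1 nitrogen, 1 sulfur, 1 chlorine; one six-membered aromatic ring of carbon only), on an amine nitrogen.

Within the data shown here, the one measured step that bears on this change is a number 10 percentage points lower from compound 1 to compound 2 (within the scatter), which also replaced the group on the double-bonded ring carbon of the shared core and produced nothing beyond the scatter. The account therefore expects no step beyond the scatter from compound 1 to compound 3 either, with the estimated step of a number 8 percentage points lower from compound 1 to compound 3 (within the scatter). Compound 3 is estimated to give 92% in this assay, within a range from 75% to 100%.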

Compound 3, a percentage reported as activity, at one concentration (the size of the read-out at that concentration, not a potency): 90%
For compound 3 the middle estimate is 2 percentage points above the measured one, and the stated range covers the measured number.
By their numbers in this assay, from the lowest: compounds 2, 3 and 1 (each within the scatter of the next).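

In this assay, keeping the amine nitrogen and exchanging only what it carries for (4-nitrophenyl)sulfonyl gives a number 10 percentage points lower from compound 1 to compound 3 (within the scatter), so the two compounds cannot be set apart. This exchange is not a close one on paper: the group that leaves has a sulfur-bearing double bond, a chlorine and 1 hydrogen-bond donor, whereas the group that enters has 0 hydrogen-bond donors, 4 hydrogen-bond acceptors and a sulfonyl link, and the read-out at this single concentration still does not separate them. Nothing measured here explains this result.

The compounds shown leave open whether a much smaller group on this amine nitrogen, such as an acetyl, or the free amine itself would give a number beyond the usual scatter. They also leave open whether compound 1 and compound 3 would differ at lower concentrations, since a read-out at one concentration that gives numbers this close says nothing about potency.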